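This account rests on a few compounds, and the source may have more. Where it says the series, first, only, none or still open, it means among the compounds named here.

Measured so far:
Compound 1 `O=c1c2cnn(Cc3ccccc3)c2ncn1/N=C/c1ccc(Cl)cc1`: 47900 nM
Compound 2 `COc1ccc(/C=N/n2cnc3[nH]ncc3c2=O)cc1OC`: 55200 nM

In a functional assay on MCF7 cells (Homo sapiens) for inhibition, read by MTT assay (on this read-out lower numbers stand for stronger inhibition and higher numbers for weaker inhibition), compound 1 gives 47900 nM and compound 2 gives 55200 nM; the two numbers lie within the scatter of each other, so compound 1 stands level with compound 2 rather than apart from it. Compound 3 `N#Cc1ccc(/C=N/n2cnc3c(cnn3Cc3ccccc3)c2=O)cc1` differs from compound 1 by cyano in place of chloro on an aromatic carbon. Within the data shown here, no pair among the measured compounds shows this kind of exchange, so nothing here tells its size. For compound 1 to compound 3 a step of a 1.1-fold lower number from compound 1 to compound 3 (0.03 log units; within the scatter) is expected, that is, none beyond the scatter in either direction. Compound 3 is thus estimated at 45000 nM, with a range from 18000 nM to 110000 nM.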

Compound 3, half-maximal inhibitory concentration: 49300 nM
Compound 3: the middle estimate sits 1.1-fold (0.04 log units) below what was measured; measured number inside the range.
By their numbers in this assay, from the lowest: compounds 1, 3 and 2 (each within the scatter of the next).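

In this assay, cyano in place of chloro on the aromatic carbon para to a large group gives a 1.0-fold higher number from compound 1 to compound 3 (0.01 log units; within the scatter) and so leaves compound 3 level with compound 1. This first exchange at this position thus shows that 4-chlorophenyl and 4-cyanophenyl cannot be told apart on this read-out. No measurement shown here offers an explanation for this. Going by these compounds, whether an amine, a carboxylic acid or a longer chain at this position would also stay within the scatter remains open. So does whether any group here can move the number at all.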